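Trifluoromethoxy for Trifluoromethyl on a Related Core

A few compounds are considered here, and "the series" means these few. Any claim that something is new, unique, unknown or untested is made for them only; others in the source may bear on it.

Compound 1 `CC(O)(CSc1ccc(C(F)(F)F)cc1)C(=O)Nc1ccc(S(F)(F)(F)(F)F)cc1`: in a functional assay on DU-145 cells (Homo sapiens) for antiproliferative activity, read by propidium iodide staining, with a stated time of 96 h (on this read-out lower numbers stand for stronger inhibition and higher numbers for weaker inhibition), compound 1 gives 28800 nM.
Compound 2 `CC(O)(CSc1ccc(OC(F)(F)F)cc1)C(=O)Nc1ccc(S(F)(F)(F)(F)F)cc1`: in this assay compound 2 gives 12500 nM.
Compound 3 `CC(O)(COc1cccc(C(F)(F)F)c1)C(=O)Nc1cccc(S(F)(F)(F)(F)F)c1`: in this assay compound 3 gives 31700 nM.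

Compound 1 and compound 2 differ by one change, (trifluoromethoxy in place of trifluoromethyl on an aromatic carbon), and it gave a 2.3-fold lower number from compound 1 to compound 2 (0.36 log units; beyond the scatter). Compound 4 `CC(O)(COc1cccc(OC(F)(F)F)c1)C(=O)Nc1cccc(S(F)(F)(F)(F)F)c1` carries the same kind of change on compound 3, (trifluoromethoxy in place of trifluoromethyl on an aromatic carbon); here the group sits meta to a large group, whereas in compound 2 it sits para to a large group. The difference between the two cores, compound 1 against compound 3, is not broken down here. Because compound 3 gives 31700 nM and the earlier change gave a 2.3-fold lower number from compound 1 to compound 2 (0.36 log units; beyond the scatter), a step of about a 2.1-fold lower number from compound 3 to compound 4 (0.32 log units; beyond the scatter) is expected in this assay, though the different place and core leave this uncertain. Compound 4 is therefore estimated at 15000 nM, expected between 7000 nM and 35000 nM.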

Compound 4, half-maximal inhibitory concentration: 30100 nM
Beside the measured number, compound 4's estimate is 2.0-fold (0.30 log units) below it, within the range that was stated.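

In this assay, putting trifluoromethoxy in place of trifluoromethyl on the core of compound 3 gave a 1.1-fold lower number from compound 3 to compound 4 (0.02 log units; within the scatter), so on this core the change made no clear difference. Set beside the same change on the other core, this step cannot be told apart from the earlier one: the same change on two cores in this assay, a 2.3-fold lower number (0.36 log units; beyond the scatter) from compound 1 to compound 2 and a 1.1-fold lower number (0.02 log units; within the scatter) from compound 3 to compound 4, 2.2-fold (0.34 log units) apart, within the scatter of two such steps The two pairs therefore neither show that the gain seen on the first core carries over nor show that it is lost, and the cores also differ in where the group sits.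

From the compounds shown here alone, whether the core or the place of the group matters more remains open. So does how a nitrile or a chlorine atom would behave in the same place on either core.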